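The source may hold more compounds than are shown below. What is called first, only, known or untested is meant among the compounds shown, and "the series" means these compounds.

Series values in a functional assay on HCT-116 cells (Homo sapiens) for inhibition, read by colorimetric assay, with a stated time of 3 days; a higher number here means a weaker inhibitor, a lower number a stronger inhibitor:
- compound 1 (`O=C(CCCCCCNC(=O)C(O)(O)C(F)(F)F)Nc1ccccc1Br`) gives 14500 nM
- compound 2 (`O=C(CCCCCCNC(=O)C(O)(O)C(F)(F)F)Nc1nc2ccc(F)cc2s1`) gives 6470 nM

Compound 2 holds the lower of the two numbers, which makes it the stronger inhibitor of this pair, and its gap to compound 1 lies beyond the usual scatter. Among the compounds with values here, with only two measured compounds, that gap supports no wider pattern.

The next compound to consider is compound 3 (`O=C(CCCCCCNC(=O)C(O)(O)C(F)(F)F)Nc1nc2ccccc2s1`), which differs from compound 2 by a single change: hydrogen in place of fluoro on an aromatic carbon. Within the data shown here, no measured pair isolates this change, so its size in this assay cannot be read from the data. The working anchor is compound 2 at 6470 nM. A small move toward a higher number is expected, with no step beyond the usual scatter.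

The estimated step of a 1.2-fold higher number from compound 2 to compound 3 (0.09 log units; within the scatter) reflects that expectation. For compound 3 the expected value is 8000 nM, with an estimated range from 3500 nM to 18000 nM.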

Compound 3, half-maximal inhibitory concentration: 2370 nM
For compound 3 the middle estimate is 3.4-fold (0.53 log units) above the measured one; the measured number lies below the stated range.
By their numbers in this assay, from the lowest: compound 3; then compound 2; then compound 1.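

In this assay, hydrogen in place of fluoro on an aromatic carbon gives a 2.7-fold lower number from compound 2 to compound 3 (0.44 log units; beyond the scatter) and this is the first pair in the series to isolate a change at this position, which shows that the position responds to its substituent and that, of the two groups shown there, hydrogen gives the lower number. Within the data shown here, the 1,3-benzothiazol-2-yl group in place of 2-bromophenyl on an amide-type nitrogen gives a 6.1-fold lower number from compound 1 to compound 3 (0.79 log units; beyond the scatter) and this single-place comparison, which the earlier compounds could not offer, shows that this group change also matters, with compound 3 holding the lowest number of the three. No supporting data bear on the reason for either step.

Only fluoro and hydrogen are shown on this aromatic carbon, so a single step leaves open how chloro, methoxy or an amine there would compare with compound 3. Going by these compounds, how a longer chain than the one shared by all three compounds would read in this assay also remains open, as does whether the fluoro step would hold on the core of compound 1.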